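The source may hold more compounds than are shown below. What is called first, only, known or untested is meant among the compounds shown, and "the series" means these compounds.

Four compounds share one core and are compared in a functional assay on the whole organism for antagonist activity, with Mus musculus as the target; a higher number here means that more compound is needed for the effect, a lower number that less compound is needed. Compound 1 `CC[S+]([O-])c1nnc(-c2ccccc2)n1C` gives 14.4 mg/kg in this assay. Compound 2 `CCS(=O)(=O)c1nnc(-c2ccccc2)n1C` differs from compound 1 by a group of 5 heavy atoms (2 carbon, 2 oxygen, 1 sulfur; no ring) in place of a group of 4 heavy atoms (2 carbon, 1 oxygen, 1 sulfur; no ring), on an aromatic carbon, and in this assay compound 2 gives 19.3 mg/kg, so that the step is a 1.3-fold higher number from compound 1 to compound 2 (0.13 log units; within the scatter). Compound 3 `CC[S+]([O-])c1nnc(-c2ccccc2F)n1C` differs from compound 1 by fluoro in place of hydrogen on an aromatic carbon; in this assay compound 3 gives 32.7 mg/kg, which makes the step of a 2.3-fold higher number from compound 1 to compound 3 (0.36 log units; beyond the scatter). Compound 4 `CCS(=O)(=O)c1nnc(-c2ccccc2F)n1C` has not yet been measured. It differs from compound 3 by a group of 5 heavy atoms (2 carbon, 2 oxygen, 1 sulfur; no ring) in place of a group of 4 heavy atoms (2 carbon, 1 oxygen, 1 sulfur; no ring), on an aromatic carbon, the same kind of change as that from compound 1 to compound 2, though the rest of the structure is not identical: compound 3 carries the fluoro and compound 1 does not. Because that earlier change made only a 1.3-fold higher number from compound 1 to compound 2 (0.13 log units; within the scatter), the step from compound 3 to compound 4 is expected to be small, about a 1.3-fold higher number from compound 3 to compound 4 (0.11 log units; within the scatter). Compound 4 is therefore estimated to give 42 mg/kg in this assay, expected to lie between 22 mg/kg and 80 mg/kg.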

Compound 4, dose for half-maximal effect: 85.8 mg/kg
Estimate against measurement, compound 4: 2.0-fold (0.31 log units) below; the measured number lies above the stated range.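

In this assay, the change to ethylsulfonyl on the fluoro-bearing core gives a 2.6-fold higher number from compound 3 to compound 4 (0.42 log units; beyond the scatter), and this step does not differ measurably from the same change on the core of compound 1: the same change on two cores in this assay, a 1.3-fold higher number (0.13 log units; within the scatter) from compound 1 to compound 2 and a 2.6-fold higher number (0.42 log units; beyond the scatter) from compound 3 to compound 4, 2.0-fold (0.29 log units) apart, within the scatter of two such steps. Fluoro in place of hydrogen, read on the ethylsulfonyl core, gives a 4.4-fold higher number from compound 2 to compound 4 (0.65 log units; beyond the scatter), and this step likewise agrees with its earlier counterpart: the same change on two cores in this assay, a 2.3-fold higher number (0.36 log units; beyond the scatter) from compound 1 to compound 3 and a 4.4-fold higher number (0.65 log units; beyond the scatter) from compound 2 to compound 4, 2.0-fold (0.29 log units) apart, within the scatter of two such steps. The two changes therefore carry over between these cores within the limits of the data, although the ethylsulfonyl step lies within the scatter on one core and beyond it on the other, and a single pair of cores for each change shows neither a true interaction between them nor how either change would behave on any further core.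

The compounds shown leave open whether a chloro or methoxy group in place of the fluoro would give a similar step. They also leave open what a longer chain in place of the ethyl, or an amine in place of the whole sulfur-bearing group, would do.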